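This account rests on a few compounds, and the source may have more. Where it says the series, first, only, none or still open, it means among the compounds named here.

Compound 1 `Fc1ccc(COc2cccc(-c3cn([C@@H]4CN5CCC4CC5)nn3)c2)cc1`: 537 nM
Compound 2 `c1ccc(COc2cccc(-c3cn([C@H]4CN5CCC4CC5)nn3)c2)cc1`: 5060 nM

Among the compounds with values here, in an assay on HEK293 cells for displacement of a labelled ligand from Neuronal acetylcholine receptor; alpha4/beta2 (Homo sapiens), read by scintillation counting, with a stated time of 120 min (a lower number here means a stronger inhibitor, a higher number a weaker inhibitor), compound 2 gives 5060 nM, the higher of the two numbers measured so far. Compound 1 gives 537 nM. Compound 1 differs from compound 2 in two places at once, so these two values show only that they lie far apart. Compound 3 `Fc1ccc(COc2cccc(-c3cn([C@H]4CN5CCC4CC5)nn3)c2)cc1` is not yet measured. It differs from compound 2 by a single change: fluoro in place of hydrogen on an aromatic carbon. Within the data shown here, no measured pair shows this change by itself, so only a small step is expected, toward a slightly lower number, close to the scatter. Compound 3 is estimated to give 3000 nM, with a range of 1000 nM to 9000 nM. That estimate means an expected step of a 1.7-fold lower number from compound 2 to compound 3 (0.23 log units; within the scatter) in this assay.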

Compound 3, inhibition constant: 6390 nM
Compound 3: middle estimate off by 2.1-fold (0.33 log units), on the low side; the measured number falls inside the stated range.
By their numbers in this assay, from the lowest: compound 1; then compounds 2 and 3 (each within the scatter of the next).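

Replacing hydrogen with fluoro, phenyl to 4-fluorophenyl, does little on this stereo form in this assay, with a 1.3-fold higher number from compound 2 to compound 3 (0.10 log units; within the scatter). Changing only the drawn configuration at the saturated ring carbon, from S to R, gives a 12-fold higher number from compound 1 to compound 3 (1.08 log units; beyond the scatter), so the large gap in this set sits at that stereocentre, not at the fluoro. One caution applies to that reading: the fact that one of compounds 1 and 3 is drawn with a defined configuration and the other without, at the place where they differ.

The compounds shown leave open whether fluoro is equally silent on the S form. They also leave open how a methoxy group or an amine in the same place would read.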